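The source may hold more compounds than are shown below. What is called first, only, known or untested is meant among the compounds shown, and "the series" means these compounds.

In a functional assay on the whole organism (stomach) with Rattus norvegicus as the target (on this read-out lower numbers stand for an effect already at smaller amounts and higher numbers for an effect only at larger amounts of compound), compound 1 (`O=C(O)c1cc(NC(=O)c2ccc([N+](=O)[O-])cc2)cc(C(=O)O)c1`) gives 61.1 mg/kg and compound 2 (`O=C(O)c1ccc(C(=O)Nc2cc(C(=O)O)cc(C(=O)O)c2)cc1`) gives 32.2 mg/kg. Within the data shown here, these are the only two numbers so far, and they cannot be told apart. The next compound is compound 3 (`CCCOc1ccc(C(=O)Nc2cc(C(=O)O)cc(C(=O)O)c2)cc1`), with propoxy in place of carboxy on an aromatic carbon, para to a large group: propoxy in place of carboxy on an aromatic carbon. Among the measured compounds shown here, the only measured step at this carbon is a 1.9-fold lower number from compound 1 to compound 2 (0.28 log units; within the scatter), which stays within the scatter. For the measured compounds named here, that step exchanges nitro and carboxy, and no measured compound carries propoxy, so it bears on the new group only weakly. No step beyond the scatter is therefore expected in this assay, and no direction can be assigned, although the uncertainty is large. An estimated 1.1-fold higher number from compound 2 to compound 3 (0.04 log units; within the scatter) is expected. For compound 3 the expected value is 35 mg/kg, with an estimated range of 11 mg/kg to 110 mg/kg.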

Compound 3, dose for 50% inhibition: 78 mg/kg
Compound 3: the middle estimate sits 2.2-fold (0.35 log units) below what was measured; measured number inside the range.
By their numbers in this assay, from the lowest: compounds 2, 1 and 3 (each within the scatter of the next, the first and the last beyond it).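

In this assay this aromatic carbon now shows a step beyond the scatter: a 2.4-fold higher number from compound 2 to compound 3 (0.38 log units; beyond the scatter) with propoxy in place of carboxy, a modest change, whereas the earlier exchange of nitro for carboxy stayed within the scatter. Propoxy and nitro remain indistinguishable, with a 1.3-fold higher number from compound 1 to compound 3 (0.11 log units; within the scatter), so only the carboxy and propoxy compounds are separated, and only compound 2 and compound 3 stand apart in this series. Nothing available here accounts for that separation.

Going by these compounds, whether methoxy or a longer chain such as butoxy would read closer to compound 2 or to compound 3 stays open, as does the outcome with an amine on this carbon. On these data alone, all three compounds share the rest of the core, so the role of its two carboxylic acids also stays open.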